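Chloro for hydrogen on the core of compound 3

The source may hold more compounds than are shown below. What is called first, only, known or untested is meant among the compounds shown, and "the series" means these compounds.

Measured so far:
- compound 1, `ClCc1ccccc1Cn1cnc2c(Cl)ncnc21`: 95500 nM
- compound 2, `ClCc1ccc(Cn2cnc3nc(Cl)nc(Cl)c32)cc1`: 6600 nM
- compound 3, `ClCc1ccccc1Cn1cnc2ncnc(Cl)c21`: 42700 nM

In a functional assay on SN12C cells (Homo sapiens) for cytotoxicity, read by sulforhodamine B assay, with a stated time of 48 h (a lower number here means that less compound is tolerated, a higher number that more compound is tolerated), compound 3 gives 42700 nM. Among the three numbers compound 3 stands second highest: compound 1 gives 95500 nM, the nearest number and beyond the scatter above it; compound 2 gives 6600 nM, the furthest number and well below it.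

Compound 4, `ClCc1ccccc1Cn1cnc2nc(Cl)nc(Cl)c21`, has not been measured. It differs from compound 3 by chloro in place of hydrogen on an aromatic carbon. Among the measured compounds shown here, no step between measured compounds that differ in one place is available, so the size of this step cannot be read off directly. Compound 2 carries the same pair of chloro groups on its core as compound 4 but differs in where its chloromethyl group stands, so it offers only an indirect pointer. In this assay compound 2 gives 6600 nM, the lowest number of the series, which suggests that the pair of chloro groups on the core goes with a lower number.

On that basis a step from compound 3 to compound 4 of a 3.6-fold lower number from compound 3 to compound 4 (0.55 log units; beyond the scatter) is expected, downward and beyond the scatter. Compound 4 is estimated at 12000 nM, with a range from 3000 nM to 45000 nM.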

Compound 4, concentration lethal to 50% of the cells: 5620 nM
For compound 4 the middle estimate is 2.1-fold (0.33 log units) above the measured one, and the stated range covers the measured number.
By their numbers in this assay, from the lowest: compounds 4 and 2 (each within the scatter of the next); then compound 3; then compound 1.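

In this assay the series now has its first measured single change, a 7.6-fold lower number from compound 3 to compound 4 (0.88 log units; beyond the scatter), for chloro in place of hydrogen on an aromatic carbon between two ring nitrogen atoms, so the number responds to substitution at this position of the core. With chloro at this position, compound 4 gives 5620 nM and compound 2 gives 6600 nM, two numbers within the scatter of each other, although the chloromethyl group stands in a different place in each. Nothing measured here bears on the cause of the step.

This one replacement leaves open whether the lower number is specific to chloro or would also follow from an amine, a methoxy group or a longer chain at the same position. It also leaves open whether a step of similar size would appear with the chloromethyl group placed as in compound 2, and whether the step would carry over to cells other than those of this assay.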